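This account rests on a few compounds, and the source may have more. Where it says the series, first, only, none or still open, it means among the compounds named here.

Measured in a functional assay on SK-BR-3 cells (Homo sapiens) for antiproliferative activity, read by MTT assay, with a stated time of 72 h; a lower number here means a stronger inhibitor, a higher number a weaker inhibitor:
- compound 1 `C/C=C1/[C@H](O[C@@H]2O[C@H](CO)[C@@H](O)[C@H](O)[C@H]2O)OC=C(C(=O)OC)[C@H]1CC(=O)OCCCCCCCCCCCCCCC`: 1600 nM
- compound 2 `C#CCOC(=O)C[C@@H]1C(C(=O)OC)=CO[C@@H](O[C@@H]2O[C@H](COC(C)=O)[C@@H](OC(C)=O)[C@H](OC(C)=O)[C@H]2OC(C)=O)/C1=C/C`: > 15000 nM
- compound 3 `C/C=C1/[C@H](O[C@@H]2O[C@H](CO)[C@@H](O)[C@H](O)[C@H]2O)OC=C(C(=O)OC)[C@H]1CC(=O)OCCC1CCCCC1`: 2000 nM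

Compound 2 gives > 15000 nM, which is a limit and not a number. Compound 3 at 2000 nM and compound 1 at 1600 nM lie within the scatter of each other.

Compound 4 `C/C=C1/[C@H](O[C@@H]2O[C@H](CO)[C@@H](O)[C@H](O)[C@H]2O)OC=C(C(=O)OC)[C@H]1CC(=O)OCCc1ccc(O)c(O)c1` has 3,4-dihydroxyphenyl in place of cyclohexyl on a saturated chain carbon, two bonds along the chain from an oxygen next to a carbonyl group. Within the data shown here, no measured compound carries this group, and no measured step guides the size of the change. The expected step, a 6.0-fold higher number from compound 3 to compound 4 (0.78 log units; beyond the scatter), is towards a higher number in this assay, beyond the scatter. For compound 4 the estimated value is 12000 nM, with an expected range of 3000 nM to 50000 nM.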

Compound 4, half-maximal inhibitory concentration: 160000 nM
Beside the measured number, compound 4's estimate is 13-fold (1.12 log units) below it; measured number outside the range, above it.
By their numbers in this assay, from the lowest: compounds 1 and 3 (each within the scatter of the next); then compound 4.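

Among these compounds, this is the first step read at this position, on a saturated chain carbon, two bonds along the chain from an oxygen next to a carbonyl group, and it shows that the position is sensitive to the group it carries. In this assay, 3,4-dihydroxyphenyl in place of cyclohexyl gives an 80-fold higher number from compound 3 to compound 4 (1.90 log units; beyond the scatter). Nothing shown gives a cause for this step.

Among the compounds shown here, the single step does not separate the aromatic ring from its two hydroxyl groups. A plain phenyl, a 4-hydroxyphenyl or a 3,4-dimethoxyphenyl at this position remains an open comparison.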